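Benzoxazole analogues in a glioblastoma cell growth assay

A few compounds are considered here, and "the series" means these few. Any claim that something is new, unique, unknown or untested is made for them only; others in the source may bear on it.

Measured compounds:
compound 1 `COc1ccc(-c2nc3cccc(-c4cc(OC)c(OC)c(OC)c4)c3o2)cc1OC` — 1300 nM
compound 2 `COc1cc(-c2cccc3nc(-c4cccc(O)c4)oc23)cc(OC)c1OC` — 5500 nM
compound 3 `COc1cc(-c2nc3cccc(-c4cc(OC)c(OC)c(OC)c4)c3o2)ccc1O` — 10300 nM

Three compounds sharing one core were tested in a functional assay on U-251 cells (Homo sapiens) for antiproliferative activity, read by MTT assay, with a stated time of 48 h; a lower number here means a stronger inhibitor, a higher number a weaker inhibitor. Compound 1 gives 1300 nM and stands at the lowest number of the three, with compound 2 at the nearest and compound 3 at the furthest. The step of a 4.2-fold higher number from compound 1 to compound 2 (0.63 log units; beyond the scatter) came with a 3-hydroxyphenyl in place of the 3,4-dimethoxyphenyl, and the step of a 7.9-fold higher number from compound 1 to compound 3 (0.90 log units; beyond the scatter) with a hydrogen in place of a methyl on an oxygen; the pair a 1.9-fold higher number from compound 2 to compound 3 (0.27 log units; within the scatter) lies within the scatter.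

Compound 4 `COc1cc(-c2cccc3nc(-c4cccc(N)c4)oc23)cc(OC)c1OC` differs from compound 1 in one place: 3-aminophenyl in place of 3,4-dimethoxyphenyl on an aromatic carbon. The step most closely bearing on it is a 4.2-fold higher number from compound 1 to compound 2 (0.63 log units; beyond the scatter), where the same ring position carried a single small group in place of the 3,4-dimethoxyphenyl, and a step of similar size and direction is expected in this assay here. Compound 4 is therefore estimated at 4500 nM in this assay, within 1500 nM to 13000 nM, a step of a 3.5-fold higher number from compound 1 to compound 4 (0.54 log units; beyond the scatter).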

Compound 4, half-maximal inhibitory concentration: 2200 nM
Compound 4: the middle estimate sits 2.0-fold (0.31 log units) above what was measured; the measured number falls inside the stated range.
By their numbers in this assay, from the lowest: compounds 1 and 4 (each within the scatter of the next); then compounds 2 and 3 (each within the scatter of the next).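

In this assay, the 3-aminophenyl replaces the 3,4-dimethoxyphenyl on this aromatic carbon with only a 1.7-fold higher number from compound 1 to compound 4 (0.23 log units; within the scatter), so, unlike the 3-hydroxyphenyl of compound 2, this smaller ring leaves no step beyond the scatter. For the compounds shown here, the single group on that ring also matters, since amino in place of hydroxy gives a 2.5-fold lower number from compound 2 to compound 4 (0.40 log units; beyond the scatter), and the comparison with the 4-hydroxy-3-methoxyphenyl gives a 4.7-fold lower number from compound 3 to compound 4 (0.67 log units; beyond the scatter). Nothing available here explains why the amino and hydroxy compounds differ.

On these data alone, it remains open whether a dimethylamino group, an acetamide or a carboxylic acid in place of the amino group would stay level with compound 1. Also open, as far as these compounds go, is whether the methoxy groups on the other phenyl ring of compound 4 can be exchanged for a fluorine or a chlorine.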